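This account rests on a few compounds, and the source may have more. Where it says the series, first, only, none or still open, it means among the compounds named here.

In an ADME assay on MT4 cells (Homo sapiens) for cytotoxicity, read by MTT assay, with a stated time of 5 days (on this read-out lower numbers stand for higher toxicity in this test and higher numbers for lower toxicity in this test), compound 1 (`N#Cc1ccc(Nc2nccc(OCc3ccccc3F)n2)cc1`) gives 151000 nM, compound 2 (`Cc1ccc(COc2ccnc(Nc3ccc(C#N)cc3)n2)cc1`) gives 81000 nM and compound 3 (`N#Cc1ccc(Nc2nccc(OCc3cc(F)ccc3Br)n2)cc1`) gives 190000 nM. These compounds differ only in the phenyl group on a saturated chain carbon bound to an oxygen on an aromatic ring. Compound 3 shares the upper end of this narrow range with compound 1, and compound 2 lies lower. The steps to compound 3 are a 1.3-fold higher number from compound 1 to compound 3 (0.10 log units; within the scatter) and a 2.3-fold higher number from compound 2 to compound 3 (0.37 log units; beyond the scatter).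

Compound 4 (`N#Cc1ccc(Nc2nccc(OCc3ccc(Br)cc3F)n2)cc1`) has the same atoms, with 4-bromo-2-fluorophenyl in place of 2-bromo-5-fluorophenyl on a saturated chain carbon bound to an oxygen on an aromatic ring. Among the measured compounds shown here, no measured pair shows this kind of rearrangement, so the evidence is indirect. The largest step at this place is only modest, a 2.3-fold higher number from compound 2 to compound 3 (0.37 log units; beyond the scatter), and the remaining one not involving compound 3 is a 1.9-fold lower number from compound 1 to compound 2 (0.27 log units; within the scatter). No step beyond the scatter is therefore expected in this assay. The expected step is a 1.3-fold lower number from compound 3 to compound 4 (0.10 log units; within the scatter). Compound 4 is expected at 150000 nM, with an estimated range of 80000 nM to 260000 nM.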

Compound 4, half-maximal cytotoxic concentration: 141000 nM
Beside the measured number, compound 4's estimate is 1.1-fold (0.03 log units) above it, and the stated range covers the measured number.
By their numbers in this assay, from the lowest: compounds 2, 4, 1 and 3 (each within the scatter of the next, the first and the last beyond it).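

In this assay, rearranging the same atoms from 2-bromo-5-fluorophenyl to 4-bromo-2-fluorophenyl on a saturated chain carbon bound to an oxygen on an aromatic ring gives a 1.3-fold lower number from compound 3 to compound 4 (0.13 log units; within the scatter) at this position. Bromo in place of hydrogen on an aromatic carbon gives a 1.1-fold lower number from compound 1 to compound 4 (0.03 log units; within the scatter) and 4-bromo-2-fluorophenyl in place of 4-methylphenyl gives a 1.7-fold higher number from compound 2 to compound 4 (0.24 log units; within the scatter), so among the four compounds only a 2.3-fold higher number from compound 2 to compound 3 (0.37 log units; beyond the scatter) remains as a step of that kind. No measurement here bears on the reason for these steps.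

All four compounds carry a substituted phenyl group at this place. The compounds shown leave open whether an amine, a carboxylic acid or a longer chain there would give a number outside this narrow range.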